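This account rests on a few compounds, and the source may have more. Where it says the series, first, only, none or still open, it means among the compounds named here.

Working notes on the series, read in a functional assay on U-937 cells (Homo sapiens) for antiproliferative activity, read by MTT assay, with a stated time of 24 h; on this read-out higher numbers stand for weaker inhibition and lower numbers for stronger inhibition. Compound 1 (`CCCCc1oc2ccccc2c1C(=O)c1ccc(OCC(=O)Nc2ccccc2)cc1`) gives 25900 nM, compound 2 (`CCCCc1oc2ccccc2c1C(=O)c1ccc(OCC(=O)Nc2cccc(OC)c2)cc1`) gives 24200 nM, and compound 3 (`CCCCc1oc2ccccc2c1C(=O)c1ccc(OCC(=O)N[C@H](C)c2ccccc2)cc1`) gives 19800 nM. Compound 3 cannot be separated from the other two: a 1.3-fold lower number from compound 1 to compound 3 (0.12 log units; within the scatter) and a 1.2-fold lower number from compound 2 to compound 3 (0.09 log units; within the scatter) lie within the scatter, as does a 1.1-fold lower number from compound 1 to compound 2 (0.03 log units; within the scatter).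

Compound 4 (`CCCCNC(=O)CCCOc1ccc(C(=O)c2c(CCCC)oc3ccccc23)cc1`) differs from compound 3 by 2-(butylcarbamoyl)ethyl in place of (1-phenylethyl)carbamoyl on a saturated chain carbon bound to an oxygen on an aromatic ring. Within the data shown here, the entering group has no ring, and no measured compound shows such a change, so the precedent is weak. The two steps on the amide-type nitrogen, a 1.3-fold lower number from compound 1 to compound 3 (0.12 log units; within the scatter) and a 1.2-fold lower number from compound 2 to compound 3 (0.09 log units; within the scatter), are the nearest guide, and both are small. No step beyond the scatter is therefore expected. The estimated step is a 1.2-fold higher number from compound 3 to compound 4 (0.07 log units; within the scatter). For compound 4 the estimated value is 23000 nM, with an expected range of 11000 nM to 48000 nM.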

Compound 4, half-maximal inhibitory concentration: 24600 nM
Estimate against measurement, compound 4: 1.1-fold (0.03 log units) below; measured number inside the range.
By their numbers in this assay, from the lowest: compounds 3, 2, 4 and 1 (each within the scatter of the next).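

In this assay, the change to 2-(butylcarbamoyl)ethyl, which has no ring, leaves compound 4 inseparable from all three earlier compounds (a 1.2-fold higher number from compound 3 to compound 4 (0.09 log units; within the scatter); a 1.0-fold higher number from compound 2 to compound 4 (0.01 log units; within the scatter); a 1.1-fold lower number from compound 1 to compound 4 (0.02 log units; within the scatter)). At this position on a saturated chain carbon bound to an oxygen on an aromatic ring, neither a six-membered aromatic ring nor a defined stereocentre in the group is needed for a value at this level. No measured evidence bears on this result.

From the compounds shown here alone, whether a carboxylic acid or an amine in place of 2-(butylcarbamoyl)ethyl would give a step beyond the scatter stays open. The same holds for a longer chain on the amide-type nitrogen.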